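Benzyl Versus Aryl Amides: Expected Loss for Compound 3

This account rests on a few compounds, and the source may have more. Where it says the series, first, only, none or still open, it means among the compounds named here.

Compound 1 `COc1ccc2c(=O)c(/C=C/C(=O)NCc3ccccc3F)coc2c1`: in a functional assay on HeLa cells (Homo sapiens) for inhibition, read by MTT assay, with a stated time of 48 h (on this read-out higher numbers stand for weaker inhibition and lower numbers for stronger inhibition), compound 1 gives > 100000 nM, which is a limit of the assay rather than a number.
Compound 2 `COc1ccc(NC(=O)/C=C/c2coc3cc(OC)ccc3c2=O)cc1`: in this assay compound 2 gives 13000 nM.

For the measured compounds named here, compound 2 holds the only actual number in this small set; the other value is a limit. The step of an at least 7.6-fold lower number from compound 1 to compound 2 (0.88 log units; beyond the scatter) shows that replacing a benzyl-type substituent on the amide nitrogen with a directly attached aromatic ring went along with stronger inhibition, although the size of that step is fixed only by the limit of > 100000 nM in this assay, at which 1 of the 2 values shown sits. Compound 3 `COc1ccc(CNC(=O)/C=C/c2coc3cc(OC)ccc3c2=O)cc1` differs from compound 2 by 4-methoxybenzyl in place of 4-methoxyphenyl on an amide-type nitrogen. Going by the values given here, this change moves back toward the benzyl-type pattern seen in compound 1, so the single measured step bears on it in reverse. Compound 3 is therefore expected to inhibit more weakly, an estimated step of a 3.1-fold higher number from compound 2 to compound 3 (0.49 log units; beyond the scatter). The estimate for compound 3 is 40000 nM, with a range from 10000 nM to 150000 nM and a real chance that only a limit is reported.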

Compound 3, half-maximal inhibitory concentration: > 100000 nM
Compound 3 was reported as a limit; the forecaster's own chance of this, stated with the estimate: 35%; at least 2.5-fold (0.39 log units) between middle value and limit.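

In this assay, the ring and its methoxy group stay the same while 4-methoxybenzyl replaces 4-methoxyphenyl on the amide-type nitrogen, and this single change gives an at least 7.6-fold higher number from compound 2 to compound 3 (0.88 log units; beyond the scatter). The earlier step changed the ring substituent as well, so it could not separate the two changes; here, weaker inhibition goes with the benzyl-type attachment even without the 2-fluorobenzyl group of compound 1. The comparison of compound 1 with compound 3 cannot be read, because both values are limits: the limit of > 100000 nM in this assay, at which 2 of the 3 values shown sit.

From the compounds shown here alone, how far the ring substituent matters within the benzyl-type pair therefore remains open. The compounds shown also leave open whether a longer chain between the nitrogen and the ring, or an amine or a carboxylic acid on the ring of compound 2, would keep or strengthen inhibition.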